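Carboxymethyl to carboxy on the side chain

The compounds below may be only part of what the source reports. "The series", "measured", "known", "first", "only" and "open" are said of these compounds alone.

- compound 1 `Cc1cn(C2OC(CO[Si](C)(C)C(C)(C)C)C3(OS(=O)(=O)C=C3N)C2O[Si](C)(C)C(C)(C)C)c(=O)n(CCCNC(=O)[C@@H]2CCCN2C(=O)[C@@H](N)CC(N)=O)c1=O` gives 25000 nM
- compound 2 `Cc1cn(C2OC(CO[Si](C)(C)C(C)(C)C)C3(OS(=O)(=O)C=C3N)C2O[Si](C)(C)C(C)(C)C)c(=O)n(CCCNC(=O)[C@@H]2CCCN2C(=O)[C@@H](N)CCC(=O)O)c1=O` gives 30000 nM

Both values come from a functional assay on CCRF-CEM cells (Homo sapiens) for antiproliferative activity (on this read-out higher numbers stand for lower toxicity in this test and lower numbers for higher toxicity in this test), and lie within the scatter of each other. Compound 2 at 30000 nM therefore stands level with compound 1. Within the data shown here, compound 3 `Cc1cn(C2OC(CO[Si](C)(C)C(C)(C)C)C3(OS(=O)(=O)C=C3N)C2O[Si](C)(C)C(C)(C)C)c(=O)n(CCCNC(=O)[C@@H]2CCCN2C(=O)[C@@H](N)CC(=O)O)c1=O` differs from compound 2 by carboxy in place of carboxymethyl on a saturated chain carbon, two bonds along the chain from an amine nitrogen and a carbonyl carbon at the same place as the one measured step. Among the measured compounds shown here, that step is a 1.2-fold higher number from compound 1 to compound 2 (0.08 log units; within the scatter) and it is the only guide. No change beyond the scatter is expected in this assay for this replacement. The expected step is a 1.1-fold lower number from compound 2 to compound 3 (0.03 log units; within the scatter) in size. Compound 3 is estimated at 28000 nM with an expected range from 14000 nM to 55000 nM in this read-out.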

Compound 3, half-maximal cytotoxic concentration: >= 125000 nM
Compound 3 was reported as a limit (the forecaster's own chance of this, stated with the estimate: 15%); at least 4.4-fold (0.64 log units) between middle value and limit.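

In this assay compound 3 is reported only as a limit, >= 125000 nM. Carboxy in place of carboxymethyl gives an at least 4.1-fold higher number from compound 2 to compound 3 (0.61 log units; beyond the scatter), and hydroxy in place of amino on a carbonyl carbon gives an at least 5.0-fold higher number from compound 1 to compound 3 (0.69 log units; beyond the scatter). This position therefore tolerates some change without a step beyond the scatter, as the first measured pair showed, but the read-out moves once the shorter carboxymethyl-bearing side chain ends in the acid rather than the amide. From the compounds shown here alone, how far the true number of compound 3 lies from the limit stays open, as does whether aminomethyl or hydroxymethyl at this place would follow carboxy or carbamoyl.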